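Moving the bromine on the anilino ring

The source may hold more compounds than are shown below. What is called first, only, known or untested is meant among the compounds shown, and "the series" means these compounds.

Compound 1 `COc1ccc(Nc2nc(-c3cccc(F)c3)nc3ccc(F)cc23)cc1` and compound 2 `Fc1cccc(-c2nc(Nc3ccc(Br)cc3)c3cc(F)ccc3n2)c1` share one core and differ only in the group on the anilino ring. In a functional assay on MDA-MB-231 cells (Homo sapiens) for cytotoxicity, read by MTT assay, with a stated time of 48 h (on this read-out higher numbers stand for weaker inhibition and lower numbers for stronger inhibition), compound 1 gives 47300 nM. Compound 2 reaches only the limit of this assay, reported as > 50000 nM. The step of an at least 1.0-fold higher number from compound 1 to compound 2 (0.02 log units; that floor lies within the scatter) can therefore not be sized beyond that floor. The floor itself is described by the limit of > 50000 nM in this assay, at which 1 of the 2 values shown sits, and compound 2 is the one sitting there. Compound 3 `Fc1cccc(-c2nc(Nc3cccc(Br)c3)c3cc(F)ccc3n2)c1` is the next compound and differs from compound 2 by 3-bromophenyl in place of 4-bromophenyl on a nitrogen on an aromatic ring. For the measured compounds named here, no measured step in this set exchanges 4-bromophenyl for 3-bromophenyl; the only measured step, from compound 1 to compound 2, exchanges methoxy for bromo and ends at the floor. The measured data therefore give no reason to expect a change beyond the scatter in this assay this assay, and the expectation for compound 3 is a step of a number no higher from compound 2 to compound 3 (the limit leaves the size open). Compound 3 is expected to give 50000 nM, with a range from 20000 nM to 150000 nM, most probably again reported only as a limit.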

Compound 3, half-maximal inhibitory concentration: > 50000 nM
Compound 3: a limit, no number; the forecaster's own chance of this, stated with the estimate: 70%; the middle value lies on the limit itself.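

In this assay compound 3 gives > 50000 nM, which is a limit and not a number. The move from 4-bromophenyl to 3-bromophenyl on the nitrogen thus yields no readable value at either placing of the bromine, and the step between compound 2 and compound 3 cannot be read, while exchanging 4-methoxyphenyl for 3-bromophenyl gives an at least 1.0-fold higher number from compound 1 to compound 3 (0.02 log units; that floor lies within the scatter). Bromine at both placings now ends at the same limit, so the only value in the set that is a number remains that of compound 1: the limit of > 50000 nM in this assay, at which 2 of the 3 values shown sit.

From the compounds shown here alone, whether compound 2 and compound 3 differ at all stays open, as neither has a number to compare. Also open, going by these compounds, is whether an amine or a carboxylic acid on the anilino ring, in place of the bromine, would give a readable number in this assay.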